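The compounds below may be only part of what the source reports. "The series", "measured", "known", "first", "only" and "open" are said of these compounds alone.

Measured so far in a functional assay on HL-60 cells (Homo sapiens) for inhibition, read by CCK-8 assay, with a stated time of 48 h, tested at 20 uM; a higher number here means more inhibition of growth at the concentration tested, a lower number less inhibition of growth
Compound 1 `N#C/C(=C\c1ccccc1OS(=O)(=O)c1ccc(F)cc1)C(=O)Nc1nnc(Cc2ccc(Cl)cc2)s1` gives 20%
Compound 2 `Cc1ccc(Cc2nnc(NC(=O)/C(C#N)=C/c3ccccc3OS(=O)(=O)c3ccc(C)cc3)s2)cc1` gives 17%

Compound 2 stands within the usual scatter of compound 1, so these two values cannot be told apart. Compound 3 `Cc1ccc(Cc2nnc(NC(=O)/C(C#N)=C/c3ccccc3OS(=O)(=O)c3ccc(F)cc3)s2)cc1` is compound 2 with one change (fluoro in place of methyl on an aromatic carbon), fluoro in place of methyl on an aromatic carbon, which turns 4-methylphenyl into 4-fluorophenyl. Going by the values given here, no measured pair shows this swap alone. With compound 1 at 20% and compound 2 at 17% so close together, no shift beyond the scatter is expected in this assay here. The step of a number 2 percentage points higher from compound 2 to compound 3 (within the scatter) is expected to stay within the scatter. Compound 3 is expected to give 19% (estimated range 8% to 33%).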

Compound 3, percent growth inhibition at one concentration: 11%
The estimate for compound 3 lay 8 percentage points above the measured number, within the range that was stated.
By their numbers in this assay, from the lowest: compounds 3, 2 and 1 (each within the scatter of the next).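

In this assay, fluoro in place of methyl on an aromatic carbon, para to a large group, gives a number 6 percentage points lower from compound 2 to compound 3 (within the scatter). A second single swap, methyl in place of chloro on an aromatic carbon, gives a number 9 percentage points lower from compound 1 to compound 3 (within the scatter), so neither swap can be told apart from repeat-measurement noise in this growth read-out. No further data bear on these steps.

Going by these compounds, it remains open whether a group of another kind at the 4-position of this phenyl ring, such as an amine or a carboxylic acid, would move the number beyond the scatter.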